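Dichlorophenyl for methylphenyl on a trifluoroacetylthiophene

The compounds below may be only part of what the source reports. "The series", "measured", "known", "first", "only" and "open" are said of these compounds alone.

Compound 1 `Cc1ccc(-c2noc(-c3ccc(C(=O)C(F)(F)F)s3)n2)cc1` is a trifluoroacetyl thiophene carrying an oxadiazole that in turn bears a 4-methylphenyl group. Within the data shown here, in an assay on isolated protein for inhibition of protein deacetylase HDAC6 (Homo sapiens) (on this read-out lower numbers stand for stronger inhibition and higher numbers for weaker inhibition), compound 1 gives 860 nM, the second highest of the three numbers measured so far. Compound 2 `O=C(NCc1ccccc1)c1ccc(C(=O)C(F)(F)F)s1`, an amide lacking the oxadiazole, gives 370 nM. Compound 3 `O=C(c1ccc(-c2nc(-c3ccc(C(F)(F)F)cc3)no2)s1)C(F)(F)F` carries a trifluoromethyl where compound 1 carries a methyl. In this assay compound 3 gives 11000 nM.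

Compound 4 `O=C(c1ccc(-c2nc(-c3ccc(Cl)cc3Cl)no2)s1)C(F)(F)F` differs from compound 1 in one place: 2,4-dichlorophenyl in place of 4-methylphenyl on an aromatic carbon. Among the measured compounds shown here, the only measured step that bears on this exchange is the one from compound 1 to compound 3, which changed the same phenyl group at a single carbon and gave a 13-fold higher number from compound 1 to compound 3 (1.11 log units; beyond the scatter). For the measured compounds named here, no measured pair shows what two chlorines on that phenyl do, so the direction of the new step rests on that single comparison, where trading the methyl for another group cost a great deal. On this basis compound 4 is expected to give a weaker result than compound 1, though the uncertainty is wide; the estimated step is a 3.5-fold higher number from compound 1 to compound 4 (0.54 log units; beyond the scatter). Compound 4 is therefore expected to show about 3000 nM, with a plausible range from 800 nM to 12000 nM.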

Compound 4, half-maximal inhibitory concentration: 3000 nM
Compound 4: the middle estimate sits on the measured number at the digits printed; the measured number falls inside the stated range.
By their numbers in this assay, from the lowest: compound 2; then compound 1; then compound 4; then compound 3.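

With a 3.5-fold higher number from compound 1 to compound 4 (0.54 log units; beyond the scatter) in this assay, this position now has a second measured exchange, and it points the same way as the first, a 13-fold higher number from compound 1 to compound 3 (1.11 log units; beyond the scatter) being the other step away from 4-methylphenyl. Among the three groups shown on this carbon of the five-membered ring, 4-methylphenyl therefore carries the lowest number, and neither replacement goes against that pattern, although the step to 2,4-dichlorophenyl is the modest one and the step to the trifluoromethyl-bearing phenyl is the large one. Nothing available here accounts for either step or for the difference in their sizes.

The compounds shown do not separate the contributions of the two chlorines, since a phenyl with a single chlorine, or with no substituent at all, does not appear among them, so it stays open which chlorine drives the step. On these data alone, it also stays open whether a different group on this phenyl, such as a methoxy group, an amine or a carboxylic acid, would bring the number below that of compound 1 on the same core.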